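Cyano in place of methyl: notes on compound 4

The source may hold more compounds than are shown below. What is called first, only, known or untested is meant among the compounds shown, and "the series" means these compounds.

In a functional assay on NCI-H146 cells (Homo sapiens) for cytotoxicity, with a stated time of 48 h, in the presence of a further agent that is not named here (on this read-out lower numbers stand for an effect already at smaller amounts and higher numbers for an effect only at larger amounts of compound), compound 1 (`Cc1cc(S(=O)(=O)NC(=O)c2ccc(N3CCN(Cc4ccccc4-c4ccc(Cl)cc4)CC3)cc2)ccc1N[C@H](CCN(C)C)CSc1ccccc1`) gives 28800 nM. Compound 3 (`CN(C)CC[C@H](CSc1ccccc1)Nc1ccc(S(=O)(=O)NC(=O)c2ccc(N3CCN(Cc4ccccc4-c4ccc(Cl)cc4)CC3)cc2)cc1S(C)(=O)=O`) gives 34900 nM, level with compound 1 within the scatter. Compound 2 (`CN(C)CC[C@H](CSc1ccccc1)Nc1ccc(S(=O)(=O)NC(=O)c2ccc(N3CCN(CC4=C(c5ccc(Cl)cc5)CCC4)CC3)cc2)cc1[N+](=O)[O-]`) gives 691 nM, a clearly lower number than either. Compound 1 therefore sits with compound 3 at the high end of these three values. Compound 2 differs from compound 1 in more than one place, so its value does not isolate any single change.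

Next in the series is compound 4 (`CN(C)CC[C@H](CSc1ccccc1)Nc1ccc(S(=O)(=O)NC(=O)c2ccc(N3CCN(Cc4ccccc4-c4ccc(Cl)cc4)CC3)cc2)cc1C#N`), with cyano in place of methyl on an aromatic carbon. The closest measured precedent is methylsulfonyl in place of methyl on an aromatic carbon, a 1.2-fold higher number from compound 1 to compound 3 (0.08 log units; within the scatter). That single step gives no sign that replacing the methyl moves the number in this assay, so no step beyond the scatter is expected. Compound 2, at 691 nM, also lacks the methyl and allows only a weak lean towards a lower number. The estimated change is a 1.4-fold lower number from compound 1 to compound 4 (0.14 log units; within the scatter), which is expected to stay small. For compound 4 the expected value is 21000 nM, with an estimated range of 8000 nM to 42000 nM.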

Compound 4, half-maximal effective concentration: 1930 nM
Compound 4: the middle estimate sits 11-fold (1.04 log units) above what was measured; measured number outside the range, below it.
By their numbers in this assay, from the lowest: compound 2; then compound 4; then compounds 1 and 3 (each within the scatter of the next).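

In this assay, going by these compounds alone, this aromatic carbon, ortho to a large group and meta to a large group, turns out to be sensitive to what it carries: cyano in place of methyl gives a 15-fold lower number from compound 1 to compound 4 (1.17 log units; beyond the scatter) on the shared core, while the only earlier step at this carbon stayed within the scatter (a 1.2-fold higher number from compound 1 to compound 3 (0.08 log units; within the scatter)). The same carbon also separates cyano from methylsulfonyl, with an 18-fold lower number from compound 3 to compound 4 (1.26 log units; beyond the scatter), so the nitrile stands apart from both earlier groups, and the two larger steps have a similar size whichever group it replaces. Nothing available here explains the size of these steps.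

From the compounds shown here alone, what remains open is whether this lower number belongs to the nitrile alone or would also appear with other groups on this carbon, such as trifluoromethyl, a primary carboxamide or a carboxylic acid. Going by these compounds, it is equally open whether cyano in place of methyl would give a step of similar size on the core of compound 2, which differs from compound 1 in more than one place and so cannot settle the matter.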